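This account rests on a few compounds, and the source may have more. Where it says the series, first, only, none or still open, it means among the compounds named here.

Measured compounds:

Compound 1 `COc1cc(/C=C/C(=O)NCc2ccc(OCc3nc(C)c(C)nc3C)c(OC)c2)ccc1O` — in a functional assay on SH-SY5Y cells (Homo sapiens) for cytotoxicity, read by MTT assay, with stated times of 24 h and 4 h (a lower number here means that less compound is needed, a higher number that more compound is needed for the effect), compound 1 gives 13400 nM.
Compound 2 `COc1cc(CNC(=O)/C=C/c2cccc(OC)c2OC)ccc1OCc1nc(C)c(C)nc1C` — in this assay compound 2 gives 7150 nM.
Compound 3 `COc1cc(CNC(=O)/C=C/c2cc(OC)c(OC)c(OC)c2)ccc1OCc1nc(C)c(C)nc1C` — in this assay compound 3 gives 11500 nM.

Compound 3 stands second highest of the three numbers. Its nearest neighbour is compound 1, with a 1.2-fold lower number from compound 1 to compound 3 (0.07 log units; within the scatter); its furthest is compound 2, with a 1.6-fold higher number from compound 2 to compound 3 (0.21 log units; within the scatter). Neither gap reaches beyond the scatter, so the three compounds sit as a group.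

The step to compound 4 `COc1cc(CNC(=O)/C=C/c2ccc(OC)c(OC)c2OC)ccc1OCc1nc(C)c(C)nc1C` is 2,3,4-trimethoxyphenyl in place of 3,4,5-trimethoxyphenyl on a double-bonded chain carbon bound to a double-bonded chain carbon. All three measured steps concern the same kind of change, a rearrangement or exchange of oxygen substituents on the aryl ring at that position: a 1.9-fold lower number from compound 1 to compound 2 (0.27 log units; within the scatter), a 1.2-fold lower number from compound 1 to compound 3 (0.07 log units; within the scatter) and a 1.6-fold higher number from compound 2 to compound 3 (0.21 log units; within the scatter). Every one of them stayed within the scatter. Among the measured compounds shown here, the present change, which moves the same three methoxy groups to a different pattern on the ring, has no measured counterpart that points to a larger shift, so no step beyond the scatter is expected in this assay in either direction.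

Compound 4 is therefore estimated at 10500 nM, with a range from 5000 nM to 22000 nM, which corresponds to an expected 1.1-fold lower number from compound 3 to compound 4 (0.04 log units; within the scatter).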

Compound 4, half-maximal effective concentration: 3840 nM
Estimate against measurement, compound 4: 2.7-fold (0.44 log units) above; the whole stated range lies above it.
By their numbers in this assay, from the lowest: compounds 4, 2, 3 and 1 (each within the scatter of the next, the first and the last beyond it).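

In this assay, the same three methoxy groups, rearranged as 2,3,4-trimethoxyphenyl in place of 3,4,5-trimethoxyphenyl on a double-bonded chain carbon, give a 3.0-fold lower number from compound 3 to compound 4 (0.48 log units; beyond the scatter), the first step among these ring exchanges to pass beyond the scatter, and it shows that the arrangement of the groups can register here even with the atom count unchanged. The exchange of 4-hydroxy-3-methoxyphenyl for 2,3,4-trimethoxyphenyl also passes beyond the scatter, with a 3.5-fold lower number from compound 1 to compound 4 (0.54 log units; beyond the scatter), whereas methoxy in place of hydrogen on an aromatic carbon gives a 1.9-fold lower number from compound 2 to compound 4 (0.27 log units; within the scatter), so that added methoxy group cannot be told apart from repeat variation. Nothing available explains why the rearrangement registers in this read-out.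

The compounds shown leave open whether the 2,3,4-pattern would keep its standing if its methoxy groups were exchanged for ethoxy groups, or if one of them gave way to an amine or a carboxylic acid. They also leave open whether the same step between the two trimethoxyphenyl patterns would appear with a longer chain in place of the present one, since all of these compounds share that chain and the rest of the core.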